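The compounds below may be only part of what the source reports. "The series", "measured", "known", "first", "only" and "open" are said of these compounds alone.

The series shares a piperidinyl-piperidine sulfonamide core, and the account begins with compound 1 `Cc1noc(C)c1S(=O)(=O)N1CCC(N2CCC(C)CC2)CC1`. In a functional assay on DLD-1 cells (Homo sapiens) for antiproliferative activity, read by CellTiter-Glo, with a stated time of 72 h (on this read-out higher numbers stand for weaker inhibition and lower numbers for stronger inhibition), compound 1 reaches only a limit, recorded as > 5000 nM. Among the three values to hand, compound 1 is the one that sits at the limit of > 5000 nM in this assay, at which 1 of the 3 values shown sits. Compound 2 `Cc1cc(C)c(S(=O)(=O)N2CCC(N3CCC(CCO)CC3)CC2)c(C)c1` gives 19 nM in this assay. Compound 3 `CC1CCN(C2CCN(S(=O)(=O)c3cc(F)c(Br)c(F)c3)CC2)CC1` gives 107 nM in this assay; both of these carry a substituted phenyl on the sulfonyl sulfur, while compound 1 carries the five-membered aromatic ring.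

The next compound, compound 4 `CC1CCN(C2CCN(S(=O)(=O)c3cccnc3)CC2)CC1`, is not yet measured in this assay. It differs from compound 1 in one place: pyridin-3-yl in place of 3,5-dimethyl-1,2-oxazol-4-yl on a sulfonyl sulfur. Because compound 1 is known only as a limit, the size of the step cannot be anchored exactly; compound 4 is expected to move toward stronger inhibition, but only moderately, with a step estimated as an at least 2.0-fold lower number from compound 1 to compound 4 (0.30 log units; that floor lies within the scatter). For compound 4 in this assay the estimate is 2500 nM, expected to fall between 400 nM and 10000 nM.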

Compound 4, half-maximal inhibitory concentration: 2400 nM
Compound 4: middle estimate off by 1.0-fold (0.02 log units), on the high side, within the range that was stated.
By their numbers in this assay, from the lowest: compound 2; then compound 3; then compound 4. At a limit, above all of these: compound 1.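

Going by these compounds alone, compound 4 gives the first reading of a single change on the sulfonyl sulfur, with the rest of the molecule held constant. In this assay, pyridin-3-yl in place of 3,5-dimethyl-1,2-oxazol-4-yl gives an at least 2.0-fold lower number from compound 1 to compound 4 (0.31 log units; beyond the scatter), so a six-membered aromatic ring with one hetero atom brings this series off the limit of the assay. Compound 4 differs from compound 3 in this same place, and compound 3 with its substituted phenyl gives 107 nM, while compound 4 stands at the higher number of 2400 nM.

On these data alone, the true size of the step stays open because compound 1 is known only as a limit: the limit of > 5000 nM in this assay, at which 1 of the 4 values shown sits. Also open, as far as these compounds go, is whether an amine or a carboxylic acid on the pyridin-3-yl ring would shift the number in this assay.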